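This account rests on a few compounds, and the source may have more. Where it says the series, first, only, none or still open, it means among the compounds named here.

Measured so far in a functional assay (muscle tissue) for inhibition, with Homo sapiens as the target; on this read-out higher numbers stand for weaker inhibition and lower numbers for stronger inhibition:

Compound 1 `O=C(N[C@@H](CCC(=O)N1CCN(c2cccc(NC3=NCCCN3)c2)CC1)C(=O)O)OCc1ccccc1`: 1.1 nM
Compound 2 `CCOC(=O)N[C@@H](CCC(=O)N1CCN(c2cccc(NC3=NCCCN3)c2)CC1)C(=O)O`: 2.1 nM
Compound 3 `CCNC(=O)N[C@@H](CCC(=O)N1CCN(c2cccc(NC3=NCCCN3)c2)CC1)C(=O)O`: in this assay compound 3 gives only a limit, > 10 nM

For the measured compounds named here, compounds 1 and 2 share one core and differ by phenyl in place of methyl on a saturated chain carbon bound to an oxygen next to a carbonyl group; the step of a 1.9-fold lower number from compound 2 to compound 1 (0.28 log units; within the scatter) is the only measured reading of that change. Compound 3 carries a different core, the difference being (ethylamino in place of ethoxy on a carbonyl carbon), and the step of an at least 4.7-fold higher number from compound 2 to compound 3 (0.67 log units; beyond the scatter) holds only as far as the limit allows, (the limit of > 10 nM in this assay, at which 1 of the 3 values shown sits).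

Compound 4 `O=C(NCc1ccccc1)N[C@@H](CCC(=O)N1CCN(c2cccc(NC3=NCCCN3)c2)CC1)C(=O)O` is not yet measured. From compound 3 it differs by phenyl in place of methyl on a saturated chain carbon bound to an amide-type nitrogen. This is the same kind of change as from compound 2 to compound 1, but the place is not the same: there the carbon was bound to an oxygen next to a carbonyl group, here it is bound to an amide-type nitrogen. The earlier step being within the scatter, the expected step from compound 3 to compound 4 in this assay is estimated as a step that the limit leaves unreadable from compound 3 to compound 4, resting on a 1.9-fold lower number from compound 2 to compound 1 (0.28 log units; within the scatter) and on the limit of compound 3. Compound 4 is therefore expected near 15 nM, between 5 nM and 60 nM, with a fair chance that only a limit is reported again.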

Compound 4, half-maximal inhibitory concentration: > 10 nM
Compound 4: a limit, no number (the forecaster's own chance of this, stated with the estimate: 45%); the middle value is on the limit's open side.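

In this assay compound 4 gives only a limit, > 10 nM, as compound 3 does. Whether phenyl in place of methyl acts on the core of compound 3 as it does in a 1.9-fold lower number from compound 2 to compound 1 (0.28 log units; within the scatter) cannot be said, because the step from compound 3 to compound 4 lies between two limits and cannot be read: the limit of > 10 nM in this assay, at which 2 of the 4 values shown sit. What does hold is that benzylamino on the carbonyl carbon, like ethylamino, sits apart from the two oxygen-linked groups, with an at least 4.7-fold higher number from compound 2 to compound 4 (0.67 log units; beyond the scatter) and an at least 9.0-fold higher number from compound 1 to compound 4 (0.95 log units; beyond the scatter).

Going by these compounds, how far compound 3 and compound 4 lie past the limit remains open, so no order between them can be given. Also open, on these data alone, is whether another group on the carbonyl carbon, such as a phenethylamino group, a longer chain such as butylamino, or a plain amino group, would bring the read-out back to a measurable number.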